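A Larger Group on the Amine Nitrogen

The source may report more compounds than this note shows. Statements on the series, on what has been measured and on what is new or still open speak of the compounds shown alone.

Of the compounds shown here, three sharing one core have been measured in an ADME assay on the whole organism (Rattus norvegicus, strain Sprague-Dawley) for pharmacokinetics, read by LC-MS, at a dose of 5 mg/kg by the oral route; a lower number here means less compound in the circulation, a higher number more compound in the circulation at the dose given. Compound 1 `Cc1cccc(Cl)c1CN1CCc2cc(-c3c(C)nc(C)c([C@H](OC(C)(C)C)C(=O)O)c3N3CCC(C)(C)CC3)ccc2C1` gives 9210 ng.h/mL, compound 2 `Cc1nc(C)c([C@H](OC(C)(C)C)C(=O)O)c(N2CCC(C)(C)CC2)c1-c1ccc2c(c1)CCN(Cc1cccc(F)c1C)C2` gives 14000 ng.h/mL, and compound 3 `Cc1nc(C)c([C@H](OC(C)(C)C)C(=O)O)c(N2CCC(C)(C)CC2)c1-c1ccc2c(c1)CCN(c1ncnc3c1cnn3C)C2` gives 22100 ng.h/mL. Compound 3 therefore stands clear of only one of the other two: the data show a 2.4-fold higher number from compound 1 to compound 3 (0.38 log units; beyond the scatter), but also a 1.6-fold higher number from compound 2 to compound 3 (0.20 log units; within the scatter).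

Compound 4 `Cc1nc(C)c([C@H](OC(C)(C)C)C(=O)O)c(N2CCC(C)(C)CC2)c1-c1ccc2c(c1)CCN(c1nccc(-c3cnccn3)n1)C2` keeps the core and differs from compound 3 in one place: a group of 12 heavy atoms (8 carbon, 4 nitrogen; 2 six-membered aromatic rings with 2 hetero atoms each) in place of a group of 10 heavy atoms (6 carbon, 4 nitrogen; one five-membered aromatic ring with 2 hetero atoms, one six-membered aromatic ring with 2 hetero atoms), on an amine nitrogen in a ring. Among the compounds with values here, the steps that bear on this change were all made on or close to that same nitrogen. The two already given replace a group with one six-membered aromatic ring of carbon only by the group found in compound 3, and they are small. The third, a change within the carbon-only groups, is a 1.5-fold higher number from compound 1 to compound 2 (0.18 log units; within the scatter). Within the data shown here, none of them exchanges one group of two nitrogen-bearing aromatic rings for another, so the data offer no direct precedent.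

Among the measured compounds shown here, with steps of this size as the only guide, no change beyond the scatter is expected, and the estimated outcome is a 1.4-fold lower number from compound 3 to compound 4 (0.14 log units; within the scatter). For compound 4 the estimated value is 16000 ng.h/mL, with an expected range of 7000 ng.h/mL to 36000 ng.h/mL.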

Compound 4, area under the concentration-time curve: 15100 ng.h/mL
For compound 4 the middle estimate is 1.1-fold (0.03 log units) above the measured one; low and high end bracket the measured number.
By their numbers in this assay, from the lowest: compounds 1, 2, 4 and 3 (each within the scatter of the next, the first and the last beyond it).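

In this assay, within the data shown here, the first exchange of one group of two nitrogen-bearing aromatic rings for another gives a 1.5-fold lower number from compound 3 to compound 4 (0.17 log units; within the scatter), so the amine nitrogen in a ring carries a second such group, here with 2 six-membered aromatic rings with 2 hetero atoms each, with no step beyond the scatter. Set against the two carbon-only groups, this new group gives a 1.1-fold higher number from compound 2 to compound 4 (0.03 log units; within the scatter) and a 1.6-fold higher number from compound 1 to compound 4 (0.21 log units; within the scatter), which leaves a 2.4-fold higher number from compound 1 to compound 3 (0.38 log units; beyond the scatter) as the only step among the four compounds that lies beyond the scatter, and so the gain seen with the group in compound 3 does not extend to the group in compound 4. Nothing among the data shown accounts for the size of any of these steps.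

Every group shown on this nitrogen contains an aromatic ring, so what an acetyl group, a morpholine ring or a plain methyl would do there remains open. As far as these compounds go, the rest of the core is the same throughout, so it is also open whether these steps would hold if the carboxylic acid gave way to an amide.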